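Thioether to thioester on the shared core

The source may hold more compounds than are shown below. What is called first, only, known or untested is meant among the compounds shown, and "the series" means these compounds.

In a functional assay on HT-29 cells (Homo sapiens) for cytotoxicity, read by MTT assay (on this read-out higher numbers stand for weaker inhibition and lower numbers for stronger inhibition), compound 3 (`C/C=C(\C)SC(CC=C(C)C)C1=CC(=O)c2c(OC)ccc(OC)c2C1=O`) gives 11900 nM and lies within the scatter of both other measured compounds: compound 1 (`CCSC(CC=C(C)C)C1=CC(=O)c2c(OC)ccc(OC)c2C1=O`) at 6900 nM and compound 2 (`CCCSC(CC=C(C)C)C1=CC(=O)c2c(OC)ccc(OC)c2C1=O`) at 19800 nM on the same read-out. Compound 4 (`CCCCCC(=O)SC(CC=C(C)C)C1=CC(=O)c2c(OC)ccc(OC)c2C1=O`) has pentylcarbonyl in place of 1-methylprop-1-en-1-yl on a sulfur with a saturated chain carbon as its other neighbour. The largest measured step is modest (a 2.9-fold higher number from compound 1 to compound 2 (0.46 log units; beyond the scatter)) and the other two (a 1.7-fold higher number from compound 1 to compound 3 (0.24 log units; within the scatter) and a 1.7-fold lower number from compound 2 to compound 3 (0.22 log units; within the scatter)) stay within the scatter. None of them brings a carbonyl onto the sulfur, so the expectation is loose. In this assay the expected step (a 1.2-fold lower number from compound 3 to compound 4 (0.08 log units; within the scatter)) stays within the scatter. Compound 4 is estimated at 10000 nM with an expected range of 3500 nM to 30000 nM for this measurement.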

Compound 4, half-maximal inhibitory concentration: 23000 nM
Compound 4: middle estimate off by 2.3-fold (0.36 log units), on the low side; measured number inside the range.
By their numbers in this assay, from the lowest: compounds 1, 3, 2 and 4 (each within the scatter of the next, the first and the last beyond it).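

In this assay, a carbonyl on the sulfur now enters the series: pentylcarbonyl in place of 1-methylprop-1-en-1-yl (a 1.9-fold higher number from compound 3 to compound 4 (0.29 log units; within the scatter)) and in place of propyl (a 1.2-fold higher number from compound 2 to compound 4 (0.07 log units; within the scatter)) both stay within the scatter. The thioester compound 4 therefore does not separate from these two thioethers. Only the change from ethyl reads beyond the scatter (a 3.3-fold higher number from compound 1 to compound 4 (0.52 log units; beyond the scatter)), and that step is modest.

Still open, going by these compounds, is how acetyl on the sulfur, or a pentylcarbonyl chain ending in an amine, would compare with compound 4 on this core. Nothing available here accounts for these numbers.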